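Removing the ethoxy group from compound 2

This account rests on a few compounds, and the source may have more. Where it says the series, first, only, none or still open, it means among the compounds named here.

Measured in a functional assay on HL-60 cells (Homo sapiens) for antiproliferative activity, read by MTT assay, with a stated time of 72 h; a lower number here means a stronger inhibitor, a higher number a weaker inhibitor:
Compound 1 `COc1cc(-n2ncnc2-c2ccc(Cl)cc2)cc(OC)c1OC`: > 10000 nM (a limit of the assay)
Compound 2 `CCOc1ccc(-c2ncnn2-c2cc(OC)c(OC)c(OC)c2)cc1`: 20 nM

Among the compounds with values here, compound 2 holds the only exact number so far. The value of compound 1 is a limit. Compound 3 `COc1cc(-n2ncnc2-c2ccccc2)cc(OC)c1OC` keeps the shared core and differs from compound 2 at one place: hydrogen in place of ethoxy on an aromatic carbon. Within the data shown here, one measured step bears on this change: an at least 500-fold lower number from compound 1 to compound 2 (2.69 log units; beyond the scatter), a large step in which ethoxy replaced chloro on an aromatic carbon. Losing the ethoxy is therefore expected to bring a large rise in the number in this assay. For compound 3 the estimate is 1500 nM, with an expected range of 150 nM to 10000 nM. This estimate means an expected 75-fold higher number from compound 2 to compound 3 (1.88 log units; beyond the scatter).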

Compound 3, half-maximal inhibitory concentration: > 10000 nM
Compound 3: no number, only a limit; the forecaster's own chance of this, stated with the estimate: 20%; at least 6.6-fold (0.82 log units) between middle value and limit.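

Replacing the ethoxy group with hydrogen on this aromatic carbon gives an at least 500-fold higher number from compound 2 to compound 3 (2.69 log units; beyond the scatter) in this assay. Compound 1 showed only that chloro does not serve in place of ethoxy; compound 3 shows that leaving the place bare does not serve either, so among these three compounds, only the one with ethoxy gives a measurable number. The difference between chloro and hydrogen cannot be read, because compound 1 and compound 3 both stand at a limit: the limit of > 10000 nM in this assay, at which 2 of the 3 values shown sit.

As far as these compounds go, whether the low number needs the full ethoxy group stays open. A hydroxyl group, a longer propoxy chain or an amine at this place could help to answer that.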